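The source may report more compounds than this note shows. Statements on the series, on what has been measured and on what is new or still open speak of the compounds shown alone.

In an ADME assay on MDCKII-LE cells (Canis lupus familiaris) for permeability (a lower number here means that the compound crosses the layer more slowly, a higher number that the compound crosses the layer faster), compound 2 `N#CCCCN([C@H](CCC(F)(F)F)C(N)=O)S(=O)(=O)c1ccc(Cl)cc1` gives 27.6 10^-6 cm/s and compound 1 `N#CC12CC(CN([C@H](CCC(F)(F)F)C(N)=O)S(=O)(=O)c3ccc(Cl)cc3)(C1)C2` gives 30.2 10^-6 cm/s, two values within the scatter of each other. Compound 3 `C[C@]1(C#N)C[C@@H](CN([C@H](CCC(F)(F)F)C(N)=O)S(=O)(=O)c2ccc(Cl)cc2)C1` differs from compound 2 as follows: 3-cyano-3-methylcyclobutyl in place of 2-cyanoethyl on a saturated chain carbon bound to a sulfonamide nitrogen. In words, 3-cyano-3-methylcyclobutyl stands in place of 2-cyanoethyl on a saturated chain carbon bound to a sulfonamide nitrogen. Among the measured compounds shown here, the one measured step that bears on this, also between a ring-bearing group and an open chain, is a 1.1-fold lower number from compound 1 to compound 2 (0.04 log units; within the scatter). No change beyond the scatter is therefore expected in this assay, and the expected step is a 1.1-fold higher number from compound 2 to compound 3 (0.02 log units; within the scatter). Compound 3 is estimated at 29 10^-6 cm/s, within an expected range of 17 10^-6 cm/s to 45 10^-6 cm/s.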

Compound 3, apparent permeability: 25.7 10^-6 cm/s
Beside the measured number, compound 3's estimate is 1.1-fold (0.05 log units) above it; the measured number falls inside the stated range.
By their numbers in this assay, from the lowest: compounds 3, 2 and 1 (each within the scatter of the next).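

In this assay, 3-cyano-3-methylcyclobutyl in place of 2-cyanoethyl on a saturated chain carbon bound to a sulfonamide nitrogen gives a 1.1-fold lower number from compound 2 to compound 3 (0.03 log units; within the scatter). Going from the group with two four-membered rings to the group with one gives a 1.2-fold lower number from compound 1 to compound 3 (0.07 log units; within the scatter), so the open chain, the single ring and the two rings all lie within the scatter of one another in these three compounds. No measurement at hand accounts for this. All three groups carry a nitrile. Going by these compounds, how an amine or a carboxylic acid in its place would read at this position remains open.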